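This account rests on a few compounds, and the source may have more. Where it says the series, first, only, none or still open, it means among the compounds named here.

Compound 1 `CCc1nncn1-c1ccc(OCc2ccccc2)cc1` gives 20.8 mg/kg in a functional assay on the whole organism (strain C57B/6) with Mus musculus as the target, in the maximal electroshock model; a higher number here means that more compound is needed for the effect, a lower number that less compound is needed.
Compound 2 `CCc1nncn1-c1ccc(OCc2ccc(Cl)cc2)cc1` gives 19.7 mg/kg in this assay.
Compound 3 `CCCCOc1ccc(-n2cnnc2CC)cc1` reaches only a limit of this assay, > 100 mg/kg.

Compound 1 holds the highest of the two numbers, yet its step to compound 2 stays within the scatter: a 1.1-fold lower number from compound 1 to compound 2 (0.02 log units; within the scatter). Compound 4 `CCCCCCCOc1ccc(-n2cnnc2CC)cc1` differs from compound 1 by hexyl in place of phenyl on a saturated chain carbon bound to an oxygen on an aromatic ring. Among the measured compounds shown here, the steps that bear on it are an at least 4.8-fold higher number from compound 1 to compound 3 (0.68 log units; beyond the scatter) and an at least 5.0-fold higher number from compound 2 to compound 3 (0.70 log units; beyond the scatter), in which a chain likewise replaces an aromatic ring on that carbon and the number rises to the limit of > 100 mg/kg in this assay, at which 1 of the 3 values shown sits. A rise of that kind is therefore expected here, probably again ending at the limit. Compound 4 is estimated at 100 mg/kg, within 40 mg/kg to 300 mg/kg, which would mean an expected 4.8-fold higher number from compound 1 to compound 4 (0.68 log units; beyond the scatter).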

Compound 4, dose for half-maximal effect: 8.3 mg/kg
Beside the measured number, compound 4's estimate is 12-fold (1.08 log units) above it; measured number outside the range, below it.
By their numbers in this assay, from the lowest: compound 4; then compounds 2 and 1 (each within the scatter of the next). At a limit, above all of these: compound 3.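

With a 2.5-fold lower number from compound 1 to compound 4 (0.40 log units; beyond the scatter) and a 2.4-fold lower number from compound 2 to compound 4 (0.38 log units; beyond the scatter) hexyl serves in place of the aromatic ring on this carbon, so that ring is not required for a low number in this assay here. With an at least 12-fold lower number from compound 3 to compound 4 (1.08 log units; beyond the scatter) the length of the chain, rather than the loss of the ring alone, governs the outcome at this position. Compound 3 remains a limit: the limit of > 100 mg/kg in this assay, at which 1 of the 4 values shown sits. Still open, as far as these compounds go, is whether a longer chain such as decyl lowers the number further or raises it again, and how an amine at the end of the hexyl chain would fare.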